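The compounds below may be only part of what the source reports. "The series", "measured", "known", "first", "only" and "open" are said of these compounds alone.

Working notes on the series. In an assay on HEK293 cells for agonist activity at transient receptor potential cation channel subfamily M member 8 (Homo sapiens), read by fluorescence and calcium flux, with a stated time of 15 min (a lower number here means that less compound is needed, a higher number that more compound is needed for the effect), compound 1 `Cc1ccc(OCC(=O)N(Cc2cccs2)c2cnn(C)c2)cc1` gives 63000 nM and stands highest of the two numbers in hand. The nearest measured neighbour is compound 2 `CCN(Cc1ccco1)C(=O)COc1ccc(C)cc1`, which in this assay gives 489 nM; the gap between the two values lies well beyond the scatter, and since the two differ in more than one place no single structural step can be read from it.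

Compound 3 `Cc1ccc(OCC(=O)N(Cc2cccs2)c2ccccc2)cc1` is not yet measured. It differs from compound 1 in one place: phenyl in place of 1-methyl-1H-pyrazol-4-yl on an amide-type nitrogen. Within the data shown here, no measured pair isolates this change, so the direction rests on expectation alone.

The working expectation is a step from compound 1 to compound 3 of a 3.2-fold lower number from compound 1 to compound 3 (0.50 log units; beyond the scatter), downward, of moderate size, since the high value of compound 1 in this assay, 63000 nM, leaves room for improvement. Compound 3 is accordingly estimated at 20000 nM in this assay, within a range of 3000 nM to 80000 nM.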

Compound 3, half-maximal effective concentration: 23 nM
The estimate for compound 3 lay 870-fold (2.94 log units) above the measured number, outside the stated range (below it).
By their numbers in this assay, from the lowest: compound 3; then compound 2; then compound 1.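

Among these compounds, on the amide-type nitrogen whose other neighbours are the carbonyl carbon and a saturated chain carbon, the group proves decisive in this assay: phenyl in place of 1-methyl-1H-pyrazol-4-yl gives a 2700-fold lower number from compound 1 to compound 3 (3.44 log units; beyond the scatter), the first single-place change and a large one. Both groups hold 6 heavy atoms, while the entering phenyl has 0 hydrogen-bond acceptors against 2 in the leaving group, and this single pair cannot show which difference, if any, carries the step. Nothing at hand bears on the reason for the size of this step.

Open, going by these compounds, is how this position responds to other groups, such as a pyridine ring, a cyclohexyl ring or a phenyl carrying a fluorine. Also open, on these data alone, is whether a step of this size holds with the rest of the molecule changed.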